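The source may report more compounds than this note shows. Statements on the series, on what has been measured and on what is new or still open speak of the compounds shown alone.

Values so far in a physicochemical assay for lipophilicity, using the shake flask method; a lower number here means a more polar compound, a higher number a more lipophilic compound
compound 1 `Nc1ncnc(Oc2ccc(NC(=O)C3(C(=O)Nc4ccc(F)cc4)CC3)cc2F)c1/C=N/OCCO` gives 2.37
compound 2 `CCOC(=O)CO/N=C/c1c(N)ncnc1Oc1ccc(NC(=O)C2(C(=O)Nc3ccc(F)cc3)CC2)cc1F` gives 3.15
compound 3 `CNc1ncnc(Oc2ccc(NC(=O)C3(C(=O)Nc4ccc(F)cc4)CC3)cc2F)c1/C=N/OC` gives 3.52

Compound 2 stands second of these three, with compound 3 higher and compound 1 lower, both beyond the scatter. Compound 4 `COCCCO/N=C/c1c(N)ncnc1Oc1ccc(NC(=O)C2(C(=O)Nc3ccc(F)cc3)CC2)cc1F` keeps the core of compound 2 and changes one chain, with 2-methoxyethyl in place of ethoxycarbonyl on a saturated chain carbon bound to an oxygen on an unsaturated carbon. Among the compounds with values here, one measured step touches this place: a number 0.78 log units higher from compound 1 to compound 2 (beyond the scatter). That modest step swapped hydroxymethyl for ethoxycarbonyl, a different pair of groups, so it shows that this place can matter but gives no direct size. Only a small change is therefore expected, within the scatter: a number 0.05 log units higher from compound 2 to compound 4 (within the scatter). For compound 4 the estimated value is 3.2, with an expected range from 2.8 to 3.6.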

Compound 4, partition coefficient: 3.18
Beside the measured number, compound 4's estimate is 0.02 log units above it; low and high end bracket the measured number.
By their numbers in this assay, from the lowest: compound 1; then compounds 2 and 4 (each within the scatter of the next); then compound 3.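

In this assay, the change to 2-methoxyethyl gives a number 0.03 log units higher from compound 2 to compound 4 (within the scatter), so at this place ethoxycarbonyl and its carbonyl can be replaced without a shift that stands out from the scatter. The second step, a number 0.81 log units higher from compound 1 to compound 4 (beyond the scatter), shows that a chain without an ester also stands clear of the hydroxy-ended chain of compound 1, so the ester is not needed for that gap. Nothing available explains why these chains behave alike. Going by these compounds, whether an amine or a carboxylic acid at the chain end would fall near compound 1, or near compound 2 and compound 4, remains open.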